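A few compounds are considered here, and "the series" means these few. Any claim that something is new, unique, unknown or untested is made for them only; others in the source may bear on it.

Of the compounds shown here, three sharing one core have been tested in a functional assay on the whole organism (strain A/J) for inhibition, with Mus musculus as the target, with stated times of 1 h and 18 h, at a dose of 100 umol/kg by the oral route; on this read-out higher numbers stand for more inhibition at the one dose given (going by the name of the read-out) and lower numbers for less inhibition. Compound 1 `COc1ccc(/C=N/N(C)c2ncnc3ccccc23)cc1OC` gives 86%; compound 2 `COc1ccc(/C=N/N(C)C(=O)c2ccc(OC)c(OC)c2)cc1OC` gives 65%; compound 3 `COc1ccc(C(=O)N(C)/N=C/c2ccc(OC)c(OC)c2)cc1` gives 45%, the lowest of the three numbers, with both others beyond the scatter above it. Within the data shown here, the one single-point change among the measured compounds, a number 20 percentage points lower from compound 2 to compound 3 (beyond the scatter), was a modest drop. Compound 4 `COc1ccc(/C=N/N(C)C(=O)c2ccc(Cl)cc2)cc1OC` differs from compound 3 by chloro in place of methoxy on an aromatic carbon. Among the measured compounds shown here, no measured step replaces methoxy with another group; the one step that touched a methoxy removed it, and the number fell. With that limited guide, the expected step of no change at the digits printed from compound 3 to compound 4 (within the scatter) is none beyond the scatter, though with wide uncertainty. Compound 4 is therefore estimated at 45%, within 20% to 70%.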

Compound 4, a percentage reported as inhibition, in the whole organism at one dose (the size of the read-out at that dose, not a potency): 59%
Beside the measured number, compound 4's estimate is 14 percentage points below it; low and high end bracket the measured number.
By their numbers in this assay, from the lowest: compound 3; then compounds 4 and 2 (each within the scatter of the next); then compound 1.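

Putting chloro in place of the methoxy on this aromatic ring, para to a large group, gives a number 14 percentage points higher from compound 3 to compound 4 (beyond the scatter) in this assay, so this position accepts a change of group without a loss. Set beside a number 20 percentage points lower from compound 2 to compound 3 (beyond the scatter), where hydrogen replaced a methoxy, this shows that losing a methoxy from this ring does not always lower the number, and that the incoming group matters. Nothing at hand explains the gain with chloro.

Still open, on these data alone, is how other groups would fare at this position, such as fluoro, a dimethylamino group or a carboxylic acid. Also open, as far as these compounds go, is whether the same swap would raise the number on the core of compound 1.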